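Swapping dimethylamino for diethylamino: a small change weighed

The source may report more compounds than this note shows. Statements on the series, on what has been measured and on what is new or still open speak of the compounds shown alone.

Measured compounds in a functional assay on HL-60 cells (Homo sapiens) for antiproliferative activity, read by MTT assay, with a stated time of 72 h; a lower number here means a stronger inhibitor of growth, a higher number a weaker inhibitor of growth:
- compound 1, `CN(C)/[N+]([O-])=N/Oc1cc(O/N=[N+](\[O-])N2CCCCC2)c([N+](=O)[O-])cc1[N+](=O)[O-]`, gives 4900 nM
- compound 2, `CN(C)/[N+]([O-])=N/Oc1cc(O/N=[N+](\[O-])N2CCCC2)c([N+](=O)[O-])cc1[N+](=O)[O-]`, gives 4900 nM
- compound 3, `CN(C)/[N+]([O-])=N/Oc1cc(O/N=[N+](\[O-])N2CCCC2CO)c([N+](=O)[O-])cc1[N+](=O)[O-]`, gives 2000 nM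

Compound 3 holds the lowest number of the three; the nearest is compound 1, which stands higher by a step beyond the scatter, and compound 2 stands equally far away. Compound 4, `CCN(CC)/[N+]([O-])=N/Oc1cc(O/N=[N+](\[O-])N2CCCC2CO)c([N+](=O)[O-])cc1[N+](=O)[O-]`, has not yet been measured. It differs from compound 3 in one place: diethylamino in place of dimethylamino on a double-bonded nitrogen.

Among the measured compounds shown here, none of the measured steps touches this part of the molecule. The ring change gave no change at the digits printed from compound 1 to compound 2 (within the scatter), while adding hydroxymethyl gave a 2.5-fold lower number from compound 1 to compound 3 (0.39 log units; beyond the scatter) and a 2.5-fold lower number from compound 2 to compound 3 (0.39 log units; beyond the scatter). Those steps show that changes around the saturated ring can be modest, but they say nothing about the dimethylamino group. For the measured compounds named here, with no direct precedent, the expected step is none beyond the scatter, expressed as no change at the digits printed from compound 3 to compound 4 (within the scatter). Compound 4 is therefore estimated at 2000 nM in this assay, with a likely range from 900 nM to 4500 nM.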

Compound 4, concentration for total growth inhibition: 4000 nM
Estimate against measurement, compound 4: 2.0-fold (0.30 log units) below, within the range that was stated.
By their numbers in this assay, from the lowest: compounds 3, 4, 1 and 2 (each within the scatter of the next, the first and the last beyond it).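

Among the compounds shown here, the new step is the first reading on the group at this position, a double-bonded nitrogen whose other neighbours are a double-bonded nitrogen and an oxygen. In this assay, diethylamino in place of dimethylamino gives a 2.0-fold higher number from compound 3 to compound 4 (0.30 log units; within the scatter), so going from 3 heavy atoms to 5 here, with the rest of the molecule held fixed, does not move the number beyond the usual scatter. Nothing available explains this step or links it to any property of the two groups.

This single pair cannot show whether the same swap would read alike with the piperidin-1-yl of compound 1 or the unsubstituted pyrrolidin-1-yl of compound 2. From the compounds shown here alone, how a longer chain such as dipropylamino, or a morpholine ring, would read at this position remains open.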